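A Chloropyridinyl Swap on a Kinesin Core

This account rests on a few compounds, and the source may have more. Where it says the series, first, only, none or still open, it means among the compounds named here.

Compound 1 `O=C1Nc2ccc(C(=O)c3ccco3)cc2/C1=C/c1cc(Br)c(O)c(Br)c1` and compound 2 `O=C1Nc2ccc(C(=O)c3ccco3)cc2/C1=C/c1ccc(O)nc1` share one core and differ only in the ring on the double-bonded chain carbon. In an assay on HeLa cells for inhibition of Kinesin-like protein KIF15 (Homo sapiens), read by microscopy, with stated times of 2 s and 20 s, tested at 750 nM (on this read-out lower numbers stand for less inhibition and higher numbers for more inhibition at the one concentration tested (going by the name of the read-out)), compound 1 gives 65%, whereas compound 2 gives 26.5%, the lower of the two numbers. Among the compounds with values here, the only measured step is a number 38.5 percentage points lower from compound 1 to compound 2 (beyond the scatter). Compound 3 `O=C1Nc2ccc(C(=O)c3ccco3)cc2/C1=C/c1ccnc(Cl)c1` carries 2-chloropyridin-4-yl in place of 6-hydroxypyridin-3-yl on a double-bonded chain carbon bound to a double-bonded ring carbon. Within the data shown here, no measured step exchanges one six-membered aromatic ring for another, so that lone step is only a loose guide. In this assay a change of a number 3.5 percentage points higher from compound 2 to compound 3 (within the scatter) is expected, likely within the scatter. Compound 3 is estimated at 30%, between 10% and 55%.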

Compound 3, a percentage reported as inhibition, at one concentration (the size of the read-out at that concentration, not a potency): 15.8%
For compound 3 the middle estimate is 14.2 percentage points above the measured one; measured number inside the range.
By their numbers in this assay, from the lowest: compound 3; then compound 2; then compound 1.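

In this assay, the ring on the double-bonded chain carbon matters even between two rings of equal heavy-atom count, each with one hetero atom: 2-chloropyridin-4-yl in place of 6-hydroxypyridin-3-yl gives a number 10.7 percentage points lower from compound 2 to compound 3 (beyond the scatter). Within the data shown here, replacing 3,5-dibromo-4-hydroxyphenyl with 2-chloropyridin-4-yl gives a number 49.2 percentage points lower from compound 1 to compound 3 (beyond the scatter), the largest step so far. No supporting evidence explains either step. From the compounds shown here alone, the step from 6-hydroxypyridin-3-yl changes both the group on the ring and where the ring is attached, so their separate shares remain unknown. Going by these compounds, how an amine in place of the chlorine would read also remains open.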